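The compounds below may be only part of what the source reports. "The series", "measured", "known", "first", "only" and "open" are said of these compounds alone.

Measured so far:
Compound 1, `O=C(/C=C/c1cc(O)c(O)c([N+](=O)[O-])c1)OCCc1ccccc1`: 22900 nM
Compound 2, `COc1c(O)ccc(/C=C/C(=O)OC2CC3CCC2(C)C3(C)C)c1[N+](=O)[O-]`: 32100 nM

Both compounds were tested in a functional assay on BCG823 cells (Homo sapiens) for cytotoxicity, read by MTT assay; a lower number here means a stronger inhibitor, a higher number a weaker inhibitor. Compound 1 gives 22900 nM, and compound 2 gives 32100 nM. The two numbers lie within the scatter of each other, so on the numbers shown neither compound can be called the stronger or the weaker inhibitor; compound 1 simply stands alongside compound 2.

Compound 3, `COc1cc(/C=C/C(=O)OCCc2ccccc2)cc([N+](=O)[O-])c1O`, has not yet been measured in this assay. It differs from compound 1 in one place: methyl in place of hydrogen on an oxygen on an aromatic ring. Cut one bond further out, the same change reads hydroxy to methoxy. Going by the values given here, no pair of measured compounds shows a step of this kind, so its effect must be guessed. Compound 2 already carries both a methoxy and a hydroxy group and gives 32100 nM, a number close to that of compound 1. On that basis the step is expected to be small, with no clear direction, and to stay within the scatter: an estimated 1.1-fold higher number from compound 1 to compound 3 (0.04 log units; within the scatter). Compound 3 is therefore expected to give about 25000 nM, most likely between 10000 nM and 60000 nM.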

Compound 3, half-maximal inhibitory concentration: > 300000 nM
Compound 3 ended at the assay's limit; the forecaster's own chance of this, stated with the estimate: 15%; middle value at least 12-fold (1.07 log units) away from the limit.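

The change is tiny: one methyl replaces one hydrogen on an oxygen on an aromatic ring, turning hydroxy into methoxy and adding a single carbon atom. Even so, in this assay this change produces an at least 13-fold higher number from compound 1 to compound 3 (1.11 log units; beyond the scatter), so this one place on the core of compound 1 is far from indifferent to what sits on it, something that compound 2, which differs from compound 1 in more than one place, could not show. The value of compound 3 is a limit of the assay and not a number: the limit of > 300000 nM in this assay, at which 1 of the 3 values shown sits.

The compounds shown leave open whether the effect belongs to methoxy alone or would also appear with a larger group on this oxygen, such as ethoxy, or with an amine in place of the hydroxy. They also leave open whether the same step would be as large if the ester were replaced by a carboxylic acid or an amide, and how far the true value of compound 3 lies beyond the limit.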